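A few compounds are considered here, and "the series" means these few. Any claim that something is new, unique, unknown or untested is made for them only; others in the source may bear on it.

In an assay on isolated protein for inhibition of Aromatase (Homo sapiens), read by fluorescence, tested at 1 uM (a lower number here means less inhibition, a higher number more inhibition at the concentration tested (going by the name of the read-out)), compound 1 `N#Cc1ccc(-n2ccc3ccncc32)cc1Oc1ccccc1` gives 97%. Compound 2 `Cc1cc(-n2ccc3ccncc32)ccc1C#N` reports > 99%, which is a limit of the assay rather than a number, namely (the limit of > 99% in this assay, at which 1 of the 2 values shown sits). Within the data shown here, the single measured step, a number at least 2 percentage points higher from compound 1 to compound 2 (that floor lies within the scatter), concerns methyl in place of phenoxy on an aromatic carbon, a different position from the change now considered, so it gives no direct guide. Compound 3 `Cc1cc(-n2ccc3ccncc32)ccc1Cl` differs from compound 2 by chloro in place of cyano on an aromatic carbon. Among the measured compounds shown here, with no measured step covering this exchange, compound 3 is expected to show 70%, within 35% to 95%, an expected step of a number at least 29 percentage points lower from compound 2 to compound 3 (beyond the scatter).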

Compound 3, a percentage reported as inhibition, at one concentration (the size of the read-out at that concentration, not a potency): 96%
The estimate for compound 3 lay 26 percentage points below the measured number, and the stated range ends below it.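

At this position, ortho to a methyl group, chloro in place of cyano gives a number at least 3 percentage points lower from compound 2 to compound 3 (that floor lies within the scatter) in this assay. Among these compounds, the cyano group is therefore not needed here for a high read-out, which the earlier compounds could not show. The reading for compound 2 is a limit of the assay, not a number: the limit of > 99% in this assay, at which 1 of the 3 values shown sits.

The compounds shown leave open whether compound 2 and compound 3 truly differ at all. They also leave open whether an amine or a carboxylic acid at this position would keep the read-out as high.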